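The source may report more compounds than this note shows. Statements on the series, on what has been measured and on what is new or still open speak of the compounds shown alone.

Of the compounds shown here, three have been measured in a functional assay on KM12 cells (Homo sapiens) for inhibition, read by sulforhodamine B assay, with a stated time of 48 h; on this read-out higher numbers stand for weaker inhibition and lower numbers for stronger inhibition. Compound 1 `COc1cc(-c2nn(-c3cccc(NC(=O)Nc4ccc(Cl)c(Cl)c4)c3)cc2-c2ccncc2)ccc1Cl` gives 810 nM. Compound 2 `O=C(Nc1cccc(-n2cc(-c3ccncc3)c(-c3ccc(Cl)c(O)c3)n2)c1)Nc1ccc(Cl)c(Cl)c1`, which carries a hydrogen in place of the methyl on the aromatic oxygen, gives 1010 nM. Compound 3 `COc1cc(-c2nn(-c3cccc(NC(=O)c4ccccc4)c3)cc2-c2ccncc2)ccc1Cl`, with a phenyl in place of the (3,4-dichlorophenyl)amino group on the carbonyl carbon, gives 560 nM. The two measured steps are both small: a 1.2-fold higher number from compound 1 to compound 2 (0.10 log units; within the scatter) and a 1.4-fold lower number from compound 1 to compound 3 (0.16 log units; within the scatter). Within the data shown here, compound 2 therefore sits within the scatter of both neighbours, and no compound of the three can be set apart from the others on these numbers.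

Compound 4 `O=C(Nc1cccc(-n2cc(-c3ccncc3)c(-c3ccc(Cl)c(O)c3)n2)c1)Nc1ccc(Cl)c(C(F)(F)F)c1` is not yet measured. It differs from compound 2 in one place: trifluoromethyl in place of chloro on an aromatic carbon. Among the measured compounds shown here, neither measured step touches this part of the molecule, so no direct precedent exists for the exchange of chloro against trifluoromethyl; the only guidance is that the two changes made so far elsewhere, on the aromatic oxygen and on the carbonyl carbon, both stayed within the scatter. On that basis a step of no size beyond the scatter is expected for a 1.0-fold lower number from compound 2 to compound 4 (0.00 log units; within the scatter) in this assay. Compound 4 is accordingly estimated at 1000 nM, with a range from 400 nM to 2500 nM.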

Compound 4, half-maximal inhibitory concentration: 1000 nM
Beside the measured number, compound 4's estimate shows no gap at the digits printed; low and high end bracket the measured number.
By their numbers in this assay, from the lowest: compounds 3, 1, 4 and 2 (each within the scatter of the next).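

Of the steps shown, this is the only one on the 3,4-dichlorophenyl group: in this assay, its exchange for 4-chloro-3-(trifluoromethyl)phenyl gives a 1.0-fold lower number from compound 2 to compound 4 (0.00 log units; within the scatter). With compound 2 as the reference, this aromatic carbon, ortho to a chloro group, therefore takes trifluoromethyl, with 4 heavy atoms, in place of chloro, with 1, and the two compounds cannot be told apart on these numbers. The data offer no measured basis for explaining this result.

This single exchange does not define the tolerance of the position, and a carboxylic acid, an amine or a longer chain on the same aromatic carbon could still give a step beyond the scatter. Going by these compounds, it also remains open whether the same exchange reads alike with the methyl on the aromatic oxygen, as in compound 1, or whether any change to the shared core would separate compounds in this assay.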